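Benzyl for cyclohexyl on the amide nitrogen

The compounds below may be only part of what the source reports. "The series", "measured", "known", "first", "only" and "open" are said of these compounds alone.

Compound 2 `C=CC1=C(C(=O)NC2CCCCC2)C(c2ccc(OC)cc2)OC1` is the reference point. For the measured compounds named here, in a functional assay on HeLa cells (Homo sapiens) for cytotoxicity, read by MTT assay, with a stated time of 24 h (on this read-out lower numbers stand for stronger inhibition and higher numbers for weaker inhibition), compound 2 gives 24800 nM, the only number among the three measured compounds. Compound 1 `C=CC1=C(C(=O)NCc2ccc(Cl)cc2)C(c2ccc(OC)c(OC)c2)OC1` gives > 100000 nM in this assay, a limit of the assay. Compound 3 `C=CC1=C(C(=O)NC2CCCCC2)C(c2ccc(F)cc2)OC1` gives > 100000 nM in this assay, again a limit. Going by the values given here, the one measured step, an at least 4.0-fold higher number from compound 2 to compound 3 (0.60 log units; beyond the scatter), concerns the aryl substituent and says nothing about the amide side. Compound 4 `C=CC1=C(C(=O)NCc2ccccc2)C(c2ccc(OC)cc2)OC1` differs from compound 2 by benzyl in place of cyclohexyl on an amide-type nitrogen. Among the compounds with values here, compound 1 differs from compound 2 in more than one place, so that pair yields no clean step. Within the data shown here, no measured step bears on this change. Compound 4 is therefore expected to stay close to compound 2, with a 1.2-fold higher number from compound 2 to compound 4 (0.08 log units; within the scatter) expected to lie within the scatter. Compound 4 is estimated at 30000 nM, between 10000 nM and 100000 nM.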

Compound 4, half-maximal inhibitory concentration: > 100000 nM
Compound 4 gave a limit, no number (the forecaster's own chance of this, stated with the estimate: 40%); at least 3.3-fold (0.52 log units) between middle value and limit.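

In this assay, the amide side is no longer silent: benzyl in place of cyclohexyl on the amide-type nitrogen gives an at least 4.0-fold higher number from compound 2 to compound 4 (0.60 log units; beyond the scatter). Compound 4 gives > 100000 nM, which is a limit of the assay and not a number. Compound 2 thus remains the only compound with a number, and the others sit at one ceiling: the limit of > 100000 nM in this assay, at which 3 of the 4 values shown sit.

Open, on these data alone, is whether a longer chain or an amine-bearing chain in place of cyclohexyl on the amide-type nitrogen would give a number rather than a limit. As far as these compounds go, how methoxy and benzyl act together beyond compound 4 also stays open.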